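Ethyl in place of methoxy: notes on growth inhibition

The source may hold more compounds than are shown below. What is called first, only, known or untested is meant among the compounds shown, and "the series" means these compounds.

Compound 1 `S=C(N/N=C/c1cccs1)Nc1ccccc1` and compound 2 `COc1ccc(NC(=S)N/N=C/c2cccs2)cc1` share a core, and compound 3 `CCc1ccc(NC(=S)N/N=C/c2cccs2)cc1` has not yet been measured. In a functional assay on NCI-H460 cells (Homo sapiens) for inhibition, read by sulforhodamine B assay, with a stated time of 48 h (a lower number here means a stronger inhibitor of growth, a higher number a weaker inhibitor of growth), compound 1 gives > 100000 nM, which is a limit of the assay and not a number. Compound 2 gives > 100000 nM, which is likewise a limit. Compound 2 therefore has no numerical standing, and the same is true of compound 1: the limit of > 100000 nM in this assay, at which 2 of the 2 values shown sit.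

Compound 3 carries ethyl in place of methoxy on an aromatic carbon, para to a large group: ethyl in place of methoxy on an aromatic carbon. Among the compounds with values here, the only measured step that bears on this change is a step that the two limits leave unreadable from compound 1 to compound 2, where methoxy replaces hydrogen. That step has no readable size, so it offers no scale for the new change. On that basis, no clear step is expected in this assay, and any movement away from the limit could only be towards stronger inhibition of growth. The estimated step is an at least 1.1-fold lower number from compound 2 to compound 3 (0.04 log units; that floor lies within the scatter). For compound 3 the estimated value is 90000 nM, with an expected range of 30000 nM to 200000 nM.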

Compound 3, concentration for 50% growth inhibition: > 100000 nM
Compound 3: no number, only a limit; the forecaster's own chance of this, stated with the estimate: 70%; middle value at least 1.1-fold (0.04 log units) away from the limit.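

Compound 3 also stands at a limit and not at a number, so none of the steps among compound 1, compound 2 and compound 3 can be read in this assay: the limit of > 100000 nM in this assay, at which 3 of the 3 values shown sit.

The compounds shown leave open whether any group at this place on the shared core brings growth inhibition within the readable range.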